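Ester Swap: Benzyl to Cyclobutylmethyl in a Dihydropyrimidinone Series

The source may hold more compounds than are shown below. What is called first, only, known or untested is meant among the compounds shown, and "the series" means these compounds.

Measured compounds:
compound 1 `CC1=C(C(=O)OCc2ccccc2)C(c2ccco2)NC(=O)N1`, 36%
compound 2 `CC1=C(C(=O)OCc2ccccc2)C(c2ccoc2)NC(=O)N1`, 41%

In an assay on membranes from CHO cells for displacement of a labelled ligand from adenosine receptor A1 (Homo sapiens), read by scintillation counting, with a stated time of 60 min, tested at 1 uM (on this read-out lower numbers stand for less inhibition and higher numbers for more inhibition at the one concentration tested (going by the name of the read-out)), compound 2 gives 41%, the higher of the two numbers seen so far, though compound 1 sits close by and the step of a number 5 percentage points higher from compound 1 to compound 2 (within the scatter) does not separate the two beyond the scatter. Compound 3 `CC1=C(C(=O)OCC2CCC2)C(c2ccoc2)NC(=O)N1` has not yet been tested. It differs from compound 2 by cyclobutyl in place of phenyl on a saturated chain carbon bound to an oxygen next to a carbonyl group. The one measured step concerns the furyl group on the saturated ring carbon, not the ester, so nothing shown directly bears on this change; the only guide is that the one alteration tried so far left the read-out essentially where it was. On that basis a modest downward step, a number 11 percentage points lower from compound 2 to compound 3 (beyond the scatter), is expected for compound 3, with wide uncertainty. The estimate for compound 3 in this assay is 30%, within a range from 8% to 52%.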

Compound 3, a percentage reported as inhibition, at one concentration (the size of the read-out at that concentration, not a potency): 46%
Compound 3: middle estimate off by 16 percentage points, on the low side, and the stated range covers the measured number.
By their numbers in this assay, from the lowest: compounds 1, 2 and 3 (each within the scatter of the next).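

The ester side, untouched by the earlier furyl step, now has a measured change of its own: this assay shows a number 5 percentage points higher from compound 2 to compound 3 (within the scatter) when cyclobutyl takes the place of phenyl on a saturated chain carbon bound to an oxygen next to a carbonyl group. With furan-3-yl on the shared core, the six-membered aromatic ring is therefore not required at this place to keep the read-out at this level, and the four-membered non-aromatic ring, with fewer heavy atoms, serves alike. No measurement at hand explains why the two groups read alike.

From the compounds shown here alone, it remains open whether the same swap would hold with the furan-2-yl group of compound 1. Also open, going by these compounds, is what an amine or a carboxylic acid on the ester chain, or a longer chain in place of cyclobutylmethyl, would do.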